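Swapping One Halogen for Another on a Benzyl Arm

This account rests on a few compounds, and the source may have more. Where it says the series, first, only, none or still open, it means among the compounds named here.

Two compounds sharing a common core were tested in an assay on HEK293 cells for inhibition of Steryl-sulfatase (Homo sapiens), tested at 1 uM; on this read-out higher numbers stand for a stronger effect at the one concentration tested and lower numbers for a weaker effect. Compound 1 `NS(=O)(=O)Oc1ccc2c(c1)CN(C(=O)c1cccc(N3CCC(Cc4ccccc4)CC3)c1)CC2` gives 41.9%. Compound 2 `CCN(Cc1cccc(Br)c1)c1ccc(C(=O)N2CCc3ccc(OS(N)(=O)=O)cc3C2)cc1` gives 97.2%, the higher of the two numbers, and compound 1 stands a long way lower, a gap beyond the usual scatter. Compound 3 `CCN(Cc1ccc(F)cc1)c1ccc(C(=O)N2CCc3ccc(OS(N)(=O)=O)cc3C2)cc1` has not yet been measured; it differs from compound 2 in one place: 4-fluorophenyl in place of 3-bromophenyl on a saturated chain carbon bound to a nitrogen on an aromatic ring. Within the data shown here, no step between two measured compounds that differ in only one place is available to guide an expectation, so the estimate rests on compound 2 alone. Because compound 2 already gives 97.2%, little room remains above it, and the move is expected to shift the read-out by a number 7.2 percentage points lower from compound 2 to compound 3 (within the scatter), a step within the scatter. Compound 3 is therefore estimated at 90%, with a range from 70% to 99%.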

Compound 3, a percentage reported as inhibition, at one concentration (the size of the read-out at that concentration, not a potency): 91.2%
Estimate against measurement, compound 3: 1.2 percentage points below, and the stated range covers the measured number.
By their numbers in this assay, from the lowest: compound 1; then compounds 3 and 2 (each within the scatter of the next).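

In this assay the swap of 3-bromophenyl for 4-fluorophenyl on a saturated chain carbon bound to a nitrogen on an aromatic ring gives a number 6 percentage points lower from compound 2 to compound 3 (within the scatter) and so leaves no difference that can be told apart from repeat scatter. Among these compounds, this is the first direct reading at this position, and it shows that the benzyl arm can carry either of these two halogen-bearing rings with the read-out unchanged within scatter. Nothing measured here speaks to why the two compounds read alike.

The halogen and its place on the ring differ together, so the contribution of each stays unresolved; 4-bromophenyl or 3-fluorophenyl would separate them. Also open, on these data alone, is whether this position would accept a plain phenyl, a pyridine ring or a ring carrying a carboxylic acid.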